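The compounds below may be only part of what the source reports. "The series", "measured", "known", "first", "only" and "open" are said of these compounds alone.

The three compounds measured so far:

Compound 1 `Cc1nc(O)c2cc(-c3ccc(Cl)c(OCC(=O)O)c3)c(C(C)C)cc2n1` gives > 1000 nM in a functional assay for inhibition of transient receptor potential cation channel subfamily V member 1 (Homo sapiens), read by fluorescence and calcium flux (a higher number here means a weaker inhibitor, a lower number a stronger inhibitor), which is a limit of the assay and not a number.
Compound 2 `CCc1nc(O)c2cc(-c3ccc(Cl)cc3)c(C(C)C)cc2n1` gives > 1000 nM in this assay, again a limit and not a number.
Compound 3 `COc1cc(Cl)cc(-c2cc3c(O)nc(C)nc3cc2C(C)C)c1` gives 100 nM in this assay.

Compound 1 therefore stands at the weak end of what has been seen: its result is the same limit as that of compound 2, and only compound 3 has a number in this assay. Within the data shown here, this is summarised by the limit of > 1000 nM in this assay, at which 2 of the 3 values shown sit, so the true potency of compound 1 is not known beyond the fact that it lies past that limit, and no step between measured compounds that differ in one place is available.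

Compound 4 `COCCOc1cc(-c2cc3c(O)nc(C)nc3cc2C(C)C)ccc1Cl` has not yet been measured. It differs from compound 1 by methoxymethyl in place of carboxy on a saturated chain carbon bound to an oxygen on an aromatic ring; read one bond further out, carboxymethoxy becomes 2-methoxyethoxy. Among the measured compounds shown here, compound 3, which carries a neutral methoxy group on the same ring, is the only compound with a measured number, and compound 4 likewise carries a neutral ether there. Compound 4 is therefore expected to be a stronger inhibitor than compound 1, with an estimated 250 nM, between 60 nM and 1500 nM, meaning an expected step of an at least 4.0-fold lower number from compound 1 to compound 4 (0.60 log units; beyond the scatter).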

Compound 4, half-maximal inhibitory concentration: 216 nM
Estimate against measurement, compound 4: 1.2-fold (0.06 log units) above, and the stated range covers the measured number.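

Among these compounds, at the saturated chain carbon bound to an oxygen on an aromatic ring, methoxymethyl in place of carboxy gives an at least 4.6-fold lower number from compound 1 to compound 4 (0.66 log units; beyond the scatter) in this assay, the only step so far that isolates a single change. Both groups hold 3 heavy atoms, but the hydrogen-bond donor and the double bond of carboxy are absent from methoxymethyl, so the pair shows that 2-methoxyethoxy at this place is compatible with a measurable number, whereas carboxymethoxy is not, though it does not show which difference matters. Compound 1 has a limit and not a number, and the true size of the step remains unknown because of that limit: the limit of > 1000 nM in this assay, at which 2 of the 4 values shown sit.

The compounds shown leave open whether a primary amide, a hydroxyl at the chain end, an amine such as 2-aminoethoxy, or a longer ether chain would read like methoxymethyl or like carboxy at this place. They also leave open whether the same change would give a similar step on the ethyl-bearing core of compound 2.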